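Bromo to chloro on compound 2: working notes

The source may hold more compounds than are shown below. What is called first, only, known or untested is meant among the compounds shown, and "the series" means these compounds.

Three compounds have entries in a functional assay on CNE-2 cells (Homo sapiens) for cytotoxicity, read by sulforhodamine B assay, with a stated time of 48 h; on this read-out lower numbers stand for stronger inhibition and higher numbers for weaker inhibition. Compound 1 (`COc1ccc(/C=C/C(=O)c2ccc(N)c(-c3ccc(F)cc3)c2)cc1`) gives 1600 nM. Compound 2 (`O=C(/C=C/c1ccc(Br)cc1)c1cccc(-c2cccc(F)c2)c1`) gives 10500 nM, the higher of the two numbers, and its gap to compound 1 lies beyond the scatter. Compound 3 (`COc1ccc(/C=C/C(=O)c2cccc(Br)c2)cc1`) has the entry "not determined" (no result reported), so it adds no number. Among the measured compounds shown here, compound 1 and compound 2 differ in more than one place, and no measured pair isolates a halogen exchange.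

Compound 4 (`O=C(/C=C/c1ccc(Cl)cc1)c1cccc(-c2cccc(F)c2)c1`) derives from compound 2 by chloro in place of bromo on an aromatic carbon, para to a large group, or 4-bromophenyl to 4-chlorophenyl. For the measured compounds named here, with no measured step to calibrate this exchange, the expectation in this assay is no step beyond the scatter, in either direction. The estimate is anchored on compound 2 at 10500 nM. The expected change is small, a 1.1-fold lower number from compound 2 to compound 4 (0.02 log units; within the scatter). For compound 4 the estimated value is 10000 nM, with an expected range of 5000 nM to 22000 nM.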

Compound 4, half-maximal inhibitory concentration: 9060 nM
Compound 4: middle estimate off by 1.1-fold (0.04 log units), on the high side, and the stated range covers the measured number.
By their numbers in this assay, from the lowest: compound 1; then compounds 4 and 2 (each within the scatter of the next).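

Among the compounds shown here, the exchange of bromo for chloro on the 4-bromophenyl group now gives a single-place step in this assay (a 1.2-fold lower number from compound 2 to compound 4 (0.06 log units; within the scatter)), which the earlier compounds could not provide. At this place, para to a large group, the two halogens are not told apart by this read-out. This holds for this one pair only and says nothing yet about the same exchange on another core. No available evidence explains this outcome.

Open, going by these compounds, is whether a group of another kind at this place, such as a nitrile or a carboxylic acid, would give a step beyond the scatter. Also open, on these data alone, is whether the gap between compound 1 and the halogen pair belongs to this place at all, since compound 1 differs from them in more than one place.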